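A few compounds are considered here, and "the series" means these few. Any claim that something is new, unique, unknown or untested is made for them only; others in the source may bear on it.

In an ADME assay on ECV-304 cells (Homo sapiens) for cytotoxicity, read by MTT assay, with a stated time of 72 h (on this read-out higher numbers stand for weaker inhibition and lower numbers for stronger inhibition), compound 1 (`COc1ccc(C2=C(c3cc(OC)c(OC)c(OC)c3)C(=O)C(OC(C)=O)C2)cc1`) gives 18 ug/mL as its reading. Compound 2 (`COc1ccc(C2=C(c3cc(OC)c(OC)c(OC)c3)C(=O)CC2O[SiH2]C(C)(C)C)cc1`) gives > 100 ug/mL in this assay, and this is a limit of the assay, not a number. Compound 3 (`COC(=O)c1cc(C2=C(c3cc(OC)c(OC)c(OC)c3)C(=O)CC2O[SiH2]C(C)(C)C)ccc1OC`) differs from compound 2 by one change (methoxycarbonyl in place of hydrogen on an aromatic carbon), methoxycarbonyl in place of hydrogen on an aromatic carbon, which turns 4-methoxyphenyl to 4-methoxy-3-(methoxycarbonyl)phenyl. Among the compounds with values here, no measured pair shows what this change does, so the expected shift (a number no higher from compound 2 to compound 3 (the limit leaves the size open)) is none beyond the usual scatter, in either direction. Compound 3 is estimated at 100 ug/mL in this assay, with an expected range from 40 ug/mL to 250 ug/mL for that reading.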

Compound 3, half-maximal inhibitory concentration: > 100 ug/mL
Compound 3 ended at the assay's limit; the forecaster's own chance of this, stated with the estimate: 60%; the middle value sits exactly at the limit.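

No step from compound 2 to compound 3 can be read, as both readings are limits of the assay rather than numbers: the limit of > 100 ug/mL in this assay, at which 2 of the 3 values shown sit.

Going by these compounds, whether methoxycarbonyl in place of hydrogen on an aromatic carbon shifts the reading at all stays open.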